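The source may report more compounds than this note shows. Statements on the series, on what has been measured and on what is new or still open speak of the compounds shown alone.

Measured so far in an in vitro ADME assay on microsomes from liver (Mus musculus) for metabolic stability, read by LC-MS, tested at 3 uM; on this read-out higher numbers stand for a longer-lived compound and lower numbers for a shorter-lived compound:
- compound 1 `CN1C[C@H]2CCCC[C@@]2(Cc2ccc(Cl)c(Cl)c2)C1`: 0.417 h
- compound 2 `CN1C[C@@H]2CCC[C@]2(c2ccc3ccccc3c2)C1`: 0.3 h
- compound 3 `Clc1ccc(C[C@@]23CCCC[C@@H]2CNC3)cc1Cl`: > 5 h (a limit of the assay, not a number)

Compound 2 at 0.3 h and compound 1 at 0.417 h lie within the scatter of each other. The value for compound 3 is a limit.

The next compound is compound 4 `CN1C[C@H]2CCC[C@@]2(c2ccc3ccccc3c2)C1`, the mirror image of compound 2: the two compounds have the same atoms and bonds and differ only in configuration as drawn: 2 of 2 stereo elements differ (all stereocentres are inverted: mirror images); a stereocentre at a saturated ring carbon is drawn R in compound 2 and S in compound 4; a stereocentre at a saturated ring carbon is drawn S in compound 2 and R in compound 4. No atom or bond changes, and both stereocentres at saturated ring carbons are inverted.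

For the measured compounds named here, the only measured step is large and beyond the scatter: an at least 11-fold higher number from compound 1 to compound 3 (1.07 log units; beyond the scatter). It puts hydrogen in place of methyl on an amine nitrogen in a ring, and that change does not occur here. Compound 4 keeps the methyl, as does compound 1 at 0.417 h. Going by the values given here, no pair of mirror images has been measured, so the data give no direct guide to the size or direction of such a step. The working expectation is therefore no shift beyond the scatter in this assay, with neither direction favoured. The expected step is small: a 1.2-fold higher number from compound 2 to compound 4 (0.07 log units; within the scatter). The estimate for compound 4 is 0.35 h, with an expected range from 0.15 h to 0.9 h.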

Compound 4, half-life: 0.3 h
For compound 4 the middle estimate is 1.2-fold (0.07 log units) above the measured one; the range from low to high includes it.
By their numbers in this assay, from the lowest: compounds 2, 4 and 1 (each within the scatter of the next). At a limit, above all of these: compound 3.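

In this assay, for the compounds shown here, inverting both stereocentres at saturated ring carbons gives no change at the digits printed from compound 2 to compound 4 (within the scatter), the first reading of a mirror-image pair. The comparison isolates configuration, with no group entering or leaving: the fact that compounds 2 and 4 differ only in the configuration as drawn

With the methyl kept on the amine nitrogen in the ring, the two mirror images read alike, so configuration as drawn at these two stereocentres gives no separation at this position in this assay. By contrast, on the core of compound 1, hydrogen in place of that methyl gives an at least 11-fold higher number from compound 1 to compound 3 (1.07 log units; beyond the scatter).

Compound 3 gives > 5 h, a limit of the assay, and the full size of that step stays open: the limit of > 5 h in this assay, at which 1 of the 4 values shown sits.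

Also open, going by these compounds, is whether mirror images still read alike with hydrogen, an ethyl group or an acetyl group on the amine nitrogen in the ring, in place of the methyl.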